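The source may hold more compounds than are shown below. What is called first, only, known or untested is meant among the compounds shown, and "the series" means these compounds.

Measured compounds in an ADME assay on HeLa Rh cells (Homo sapiens) for cytotoxicity, read by microscopy; a lower number here means that less compound is tolerated, a higher number that more compound is tolerated:
Compound 1 `COc1cc(CC(O)c2ccc(-c3ccc(C#N)cc3)cc2)c([N+](=O)[O-])cc1OC` gives 4700 nM.
Compound 2 `COc1cc(CC(O)c2ccc(-c3ccc(C=O)cc3)cc2)c([N+](=O)[O-])cc1OC` reaches only a limit of the assay, > 245000 nM.
Compound 3 `COc1cc(CC(O)c2ccc(-c3ccccc3[N+](=O)[O-])cc2)c([N+](=O)[O-])cc1OC` gives 9500 nM.

Of the two plain numbers in this assay, compound 1 holds the lowest; its nearest neighbour is compound 3, with a 2.0-fold higher number from compound 1 to compound 3 (0.31 log units; beyond the scatter). Compound 2 sits at a limit, as the limit of > 245000 nM in this assay, at which 1 of the 3 values shown sits, records, so no number is known for it.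

Compound 4 `COc1cc(CC(O)c2ccc(-c3cccs3)cc2)c([N+](=O)[O-])cc1OC` differs from compound 1 in one place: thiophen-2-yl in place of 4-cyanophenyl on an aromatic carbon. The change sits where both measured steps act, on the aryl group attached to the same aromatic carbon of the shared core. Those steps were an at least 52-fold higher number from compound 1 to compound 2 (1.71 log units; beyond the scatter), a large rise that ends at a limit, and a 2.0-fold higher number from compound 1 to compound 3 (0.31 log units; beyond the scatter), a modest rise. Neither step, however, swaps the whole 4-cyanophenyl for a five-membered ring, so they set only a loose frame. Both alterations at this place raised the number, and an expected rise of modest size in this assay for compound 4 seems the most reasonable reading, with the direction itself uncertain.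

Accordingly compound 4 is expected at 8000 nM, within 2500 nM to 40000 nM.

That estimate for compound 4 means an expected step of a 1.7-fold higher number from compound 1 to compound 4 (0.23 log units; within the scatter).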

Compound 4, half-maximal cytotoxic concentration: 11000 nM
The estimate for compound 4 lay 1.4-fold (0.14 log units) below the measured number, within the range that was stated.
By their numbers in this assay, from the lowest: compound 1; then compounds 3 and 4 (each within the scatter of the next). At a limit, above all of these: compound 2.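

Thiophen-2-yl in place of 4-cyanophenyl gives a 2.3-fold higher number from compound 1 to compound 4 (0.37 log units; beyond the scatter) in this assay, so at this place even the loss of the six-membered ring and the nitrile together moves the number only modestly. Set against the 2-nitrophenyl group, thiophen-2-yl gives a 1.2-fold higher number from compound 3 to compound 4 (0.06 log units; within the scatter), so compounds 3 and 4 cannot be told apart here although their aryl groups differ in ring size and in the hetero atom they carry. The other comparison is an at least 22-fold lower number from compound 2 to compound 4 (1.34 log units; beyond the scatter), which shows that among these groups the large rise belongs to 4-formylphenyl alone and not to the removal of 4-cyanophenyl as such, since compounds 3 and 4 also lack that group, while compound 2 stays a limit and not a number: the limit of > 245000 nM in this assay, at which 1 of the 4 values shown sits.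

As far as these compounds go, it remains open what a carboxylic acid or an amine in place of the formyl would give, and so whether the large rise is tied to the formyl itself. From the compounds shown here alone, it is equally open whether a furan-2-yl ring would match thiophen-2-yl, and whether these steps would hold on a changed version of the shared core.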